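Methyl added to a benzyloxy anilide in a bile acid receptor assay

This account rests on a few compounds, and the source may have more. Where it says the series, first, only, none or still open, it means among the compounds named here.

Three anilide acids have been measured in an assay on isolated protein for agonist activity at Bile acid receptor (Homo sapiens), read by TR-FRET, with a stated time of 3 h, in the absence of a further agent; a lower number here means that less compound is needed, a higher number that more compound is needed for the effect. Compound 1 `COc1ccccc1C(=O)Nc1ccc(C)c(C(=O)O)c1` reaches only the limit of the assay, giving > 10000 nM. Compound 2 `COc1ccccc1C(=O)Nc1cccc(C(=O)O)c1` likewise stops at the limit, with > 10000 nM. For the measured compounds named here, compound 3 `O=C(O)c1cccc(NC(=O)c2ccc(OCc3ccccc3)cc2)c1` gives the one real number, 135 nM in this assay; how its core differs from that of compound 2 is not broken down here.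

Compound 2 and compound 1 differ by methyl in place of hydrogen on an aromatic carbon, and the step that the two limits leave unreadable from compound 2 to compound 1 cannot be read because of the limit of > 10000 nM in this assay, at which 2 of the 3 values shown sit.

Compound 4 `Cc1cccc(COc2ccc(C(=O)Nc3cccc(C(=O)O)c3)cc2)c1` is not yet measured. It differs from compound 3 by methyl in place of hydrogen on an aromatic carbon. This is the same kind of change as from compound 2 to compound 1, but not the same: in compound 1 the methyl sits ortho to a carboxy group and para to a large group, whereas in compound 4 it sits meta to a large group. The earlier pair gives no readable guide. Starting from compound 3 and its 135 nM, the step of a 1.2-fold lower number from compound 3 to compound 4 (0.09 log units; within the scatter) is expected to be small. Compound 4 is therefore estimated at 110 nM, most likely between 40 nM and 320 nM in this assay.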

Compound 4, half-maximal effective concentration: 259 nM
For compound 4 the middle estimate is 2.4-fold (0.37 log units) below the measured one, within the range that was stated.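

In this assay, the change from benzyloxy to (3-methylbenzyl)oxy gives a 1.9-fold higher number from compound 3 to compound 4 (0.28 log units; within the scatter), so on this core the added methyl produces no readable difference. For the compounds shown here, this is a single step at a single place, meta to a large group, and it shows only that compound 4 stays in the same range as compound 3, not that methyl is neutral across the series. Whether the result carries over from one core to another cannot be said, because the only other pair with this change, compound 2 and compound 1, gives a step that cannot be read, both values being limits of the assay: the limit of > 10000 nM in this assay, at which 2 of the 4 values shown sit.

The compounds shown leave open whether a fluorine, a hydroxyl or an amine in place of this methyl would read the same way on the ring of compound 4. They also leave open how a longer chain in place of the benzyloxy link would read on the core of compound 3.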